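The source may hold more compounds than are shown below. What is called first, only, known or untested is meant among the compounds shown, and "the series" means these compounds.

Compound 1, `N#CC1CN1C(=O)Nc1ccc(Cl)cc1Cl`: 1100 nM
Compound 2, `CCCCNC(=O)N1CC1C#N`: 6700 nM
Compound 3, `N#CC1CN1C(=O)Nc1cccc2ccccc12`: 1700 nM

The measure throughout is a functional assay on MCF7 cells (Homo sapiens) for inhibition; on this read-out lower numbers stand for stronger inhibition and higher numbers for weaker inhibition. Compound 2 stands highest of the three numbers; compound 3 lies nearest to it and compound 1 furthest, and both gaps are beyond the scatter. Compound 4, `CCNC(=O)N1CC1C#N`, has not yet been measured in this assay. It differs from compound 2 in one place: hydrogen in place of ethyl on a saturated chain carbon, two bonds along the chain from an amide-type nitrogen. For the measured compounds named here, no measured pair shows a step of this kind, so the size of the step cannot be read from the numbers in hand. The shortening is expected to move the number little, with at most a modest rise that need not exceed the scatter. For compound 4 the estimate is 9000 nM, within 3000 nM to 27000 nM, which corresponds to an expected step of a 1.3-fold higher number from compound 2 to compound 4 (0.13 log units; within the scatter).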

Compound 4, half-maximal inhibitory concentration: 20000 nM
Compound 4: the middle estimate sits 2.2-fold (0.35 log units) below what was measured; measured number inside the range.
By their numbers in this assay, from the lowest: compounds 1 and 3 (each within the scatter of the next); then compound 2; then compound 4.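

In this assay, shortening butyl to ethyl gives a 3.0-fold higher number from compound 2 to compound 4 (0.47 log units; beyond the scatter). This first step read at this position shows that the chain length matters here: removing the outer ethyl weakens inhibition by more than the scatter. Nothing at hand explains this step.

As far as these compounds go, whether a longer chain than butyl, or a terminal amine or carboxylic acid on the chain, would lower the number remains open. A single step also cannot show whether the number rises evenly through propyl or changes abruptly.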